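The compounds below may be only part of what the source reports. "The series", "measured", "known", "first", "only" and "open" are said of these compounds alone.

Compound 1 `CC(C)N(Cc1cccc(OCCCCCC(=O)O)c1)C(=O)c1ccc(-c2cccc(OCc3ccccc3)c2)cc1`, compound 2 `Cc1nnc(-c2cccc(-c3ccc(C(=O)N(Cc4cccc(OCCCCCC(=O)O)c4)C(C)C)cc3)c2)o1` and compound 3 `CCOC(=O)CCCCCOc1cccc(CN(C(=O)c2ccc(-c3cccc(OCc4ccccc4)c3)cc2)C(C)C)c1` were examined in an ADME assay on HepG2 cells (Homo sapiens) for cytotoxicity, read by CellTiter-Glo and resazurin assay, with a stated time of 72 h; on this read-out lower numbers stand for an effect already at smaller amounts and higher numbers for an effect only at larger amounts of compound. Compound 1 reaches only a limit of the assay, > 26000 nM. Compound 2 likewise stops at a limit, > 26000 nM. Compound 3 also shows a limit, > 26000 nM. Because the limit of > 26000 nM in this assay, at which 3 of the 3 values shown sit, holds every value seen, the change from compound 1 to compound 2, (5-methyl-1,3,4-oxadiazol-2-yl in place of benzyloxy on an aromatic carbon), gives a step that the two limits leave unreadable from compound 1 to compound 2. The cores of compound 1 and compound 3 differ by ethyl in place of hydrogen on an oxygen next to a carbonyl group, a step that reads a step that the two limits leave unreadable from compound 1 to compound 3. Compound 4 `CCOC(=O)CCCCCOc1cccc(CN(C(=O)c2ccc(-c3cccc(-c4nnc(C)o4)c3)cc2)C(C)C)c1` carries the same change, (5-methyl-1,3,4-oxadiazol-2-yl in place of benzyloxy on an aromatic carbon). The step from compound 3 to compound 4 is expected to be a step that the limit leaves unreadable from compound 3 to compound 4. That expectation rests on compound 3 sitting at its limit > 26000 nM. It rests equally on a step that the two limits leave unreadable from compound 1 to compound 2. Compound 4 is therefore estimated at 40000 nM, between 20000 nM and 120000 nM.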

Compound 4, half-maximal effective concentration: > 26000 nM
Compound 4 gave a limit, no number; the forecaster's own chance of this, stated with the estimate: 85%; the middle value is on the limit's open side.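

No step can be read from compound 3 to compound 4 or from compound 2 to compound 4, because both members of each pair stop at a limit: the limit of > 26000 nM in this assay, at which 4 of the 4 values shown sit.

The compounds shown leave open whether either change moves the half-maximal effective concentration in this assay at all.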